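Removing a methyl group in a sulfonylguanidine series: cytotoxicity

The source may hold more compounds than are shown below. What is called first, only, known or untested is meant among the compounds shown, and "the series" means these compounds.

The measured compounds and their values in an ADME assay on HaCaT cells (Homo sapiens) for cytotoxicity, read by MTT assay, with a stated time of 72 h; on this read-out higher numbers stand for weaker inhibition and lower numbers for stronger inhibition:
- compound 1, `Cc1cccc(CSc2cc(Cl)c(C)cc2S(=O)(=O)/N=C(\N)n2nccc2-c2ccccc2)c1`, gives 10000 nM
- compound 2, `Cc1cc(S(=O)(=O)/N=C(\N)n2nccc2-c2ccccc2)c(SCc2ccccc2)cc1Cl`, gives 18000 nM
- compound 3, `Cc1cc(-c2ccccc2)n(/C(N)=N/S(=O)(=O)c2cc(C)c(Cl)cc2SCc2ccc(C(F)(F)F)cc2)n1`, gives 18000 nM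

Compound 1 and compound 2 differ in one place: hydrogen in place of methyl on an aromatic carbon. That change gives a 1.8-fold higher number from compound 1 to compound 2 (0.26 log units; within the scatter), so the two numbers cannot be told apart. Compound 3 stands level with compound 2 at the digits reported and differs from compound 1 by a gap that is also within the scatter; the difference between the core of compound 3 and the core of compound 1 is not broken down here.

Compound 4, `Cc1cc(S(=O)(=O)/N=C(\N)n2nccc2-c2ccccc2)c(SCc2ccc(C(F)(F)F)cc2)cc1Cl`, has not yet been measured in this assay. It differs from compound 3 by hydrogen in place of methyl on an aromatic carbon. This is the same kind of change as that from compound 1 to compound 2, but not the same change: there the methyl left an aromatic carbon of a six-membered aromatic ring of carbon only, meta to a large group, whereas here it leaves an aromatic carbon of a five-membered aromatic ring with 2 nitrogen, next to the ring nitrogen, two ring bonds from the ring atom that bears a large group and two ring bonds from the ring atom that bears a phenyl group.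

Going by the values given here, because the only measured example of this kind of change, a 1.8-fold higher number from compound 1 to compound 2 (0.26 log units; within the scatter), stayed within the scatter, the expected step is a 1.1-fold higher number from compound 3 to compound 4 (0.05 log units; within the scatter). Compound 4 is accordingly estimated at 20000 nM, with a likely range from 8000 nM to 50000 nM.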

Compound 4, half-maximal inhibitory concentration: 19000 nM
Compound 4: the middle estimate sits 1.1-fold (0.02 log units) above what was measured, within the range that was stated.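

In this assay, hydrogen in place of methyl gives a 1.1-fold higher number from compound 3 to compound 4 (0.02 log units; within the scatter), and set beside the earlier step, the change reads alike on the two cores: the same change on two cores in this assay, a 1.8-fold higher number (0.26 log units; within the scatter) from compound 1 to compound 2 and a 1.1-fold higher number (0.02 log units; within the scatter) from compound 3 to compound 4, 1.7-fold (0.23 log units) apart, within the scatter of two such steps. The other two new steps, a 1.1-fold higher number from compound 2 to compound 4 (0.02 log units; within the scatter) with trifluoromethyl in place of hydrogen on an aromatic carbon and a 1.9-fold higher number from compound 1 to compound 4 (0.28 log units; within the scatter) with 4-(trifluoromethyl)phenyl in place of 3-methylphenyl, also stay within the scatter, so the four compounds cannot be told apart on this read-out. This does not show that the methyl group is without consequence throughout the series: the two steps concern two different places, neither lies beyond the scatter, and together they offer no measurable effect that could be carried to a further core.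

The compounds shown leave open whether an amine or a carboxylic acid in place of the methyl on the five-membered aromatic ring with 2 nitrogen would give a number beyond the scatter. They also leave open whether a longer chain in place of the saturated chain carbon bound to a sulfur would do so.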